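Three Analogues at the Assay Limit and a Chloro-Methyl Variant

The compounds below may be only part of what the source reports. "The series", "measured", "known", "first", "only" and "open" are said of these compounds alone.

Among the compounds with values here, the three compounds measured so far share one core and differ only in the aryl group on an aromatic nitrogen. Compound 1 `N#CC1=C(N)Oc2c(c3nc4ccccc4nc3c3ccccc23)C12C(=O)N(Cc1cnnn1-c1ccc(S(N)(=O)=O)cc1)c1ccccc12` carries a 4-sulfamoylphenyl there, compound 2 `Cc1ccc(C)c(-n2nncc2CN2C(=O)C3(C(C#N)=C(N)Oc4c3c3nc5ccccc5nc3c3ccccc43)c3ccccc32)c1` a 2,5-dimethylphenyl, and compound 3 `Cc1cccc(-n2nncc2CN2C(=O)C3(C(C#N)=C(N)Oc4c(N)cc5nc6ccccc6nc5c43)c3ccccc32)c1` a 3-methylphenyl. In an ADME assay on HUVEC cells (Homo sapiens) for antiproliferative activity, read by MTT assay, with a stated time of 48 h (a lower number here means a stronger inhibitor, a higher number a weaker inhibitor), compound 1 gives only a limit, > 50000 nM. Compound 2 likewise gives only a limit in this assay, > 50000 nM. Compound 3 also gives only a limit, > 50000 nM. Within the data shown here, the single step between measured compounds that differ in one place, a step that the two limits leave unreadable from compound 1 to compound 2, is thus of unknown size. Compound 3 therefore stands at the limit of > 50000 nM in this assay, at which 3 of the 3 values shown sit, with no number of its own to build on.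

Compound 4 `Cc1ccc(-n2nncc2CN2C(=O)C3(C(C#N)=C(N)Oc4c(N)cc5nc6ccccc6nc5c43)c3ccccc32)cc1Cl` differs from compound 3 in one place: 3-chloro-4-methylphenyl in place of 3-methylphenyl on an aromatic nitrogen. Among the measured compounds shown here, the only measured step that concerns a change of the aryl group on that aromatic nitrogen is the one from compound 1 to compound 2, and it cannot be read. For the measured compounds named here, no measured step points in either direction, so the expectation for compound 4 is a step that the limit leaves unreadable from compound 3 to compound 4, none beyond the scatter. Compound 4 is therefore estimated at 80000 nM, between 25000 nM and 300000 nM, most likely reported again only as a limit.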

Compound 4, half-maximal inhibitory concentration: > 50000 nM
Compound 4: a limit, no number (the forecaster's own chance of this, stated with the estimate: 85%); the middle value is on the limit's open side.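

Compound 4 gives only a limit in this assay, > 50000 nM. The change from compound 3 to compound 4 therefore cannot be read as a step of any size. The compounds shown leave open whether any aryl group on that aromatic nitrogen gives a true number, as all of them sit at one value: the limit of > 50000 nM in this assay, at which 4 of the 4 values shown sit.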